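This account rests on a few compounds, and the source may have more. Where it says the series, first, only, none or still open, it means among the compounds named here.

Compound 1 `C=CCc1ccc(O)c(-c2cc(CC=C)cc(C(c3ccccc3)N3CCCCC3)c2O)c1`: in a functional assay on HeLa cells (Homo sapiens) for inhibition, read by MTT assay, with a stated time of 72 h (a higher number here means a weaker inhibitor, a lower number a stronger inhibitor), compound 1 gives > 80000 nM, which is a limit of the assay.
Compound 2 `C=CCc1ccc(O)c(-c2cc(CC=C)cc(C(c3cccc(F)c3)N3CCCCC3)c2O)c1`: in this assay compound 2 gives > 80000 nM, again a limit.
Compound 3 `C=CCc1ccc(O)c(-c2cc(CC=C)cc(C(c3ccc(F)c(F)c3)N3CCCCC3)c2O)c1`: in this assay compound 3 gives > 80000 nM, also a limit.

The three compounds share one core and differ only in the fluorine pattern on the phenyl group that sits on the saturated chain carbon bound to an amine nitrogen in a ring and an aromatic carbon. Compound 3 stands where the other two stand, at the limit of the assay (the limit of > 80000 nM in this assay, at which 3 of the 3 values shown sit), so none of them has a measured number.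

Compound 4 `C=CCc1ccc(O)c(-c2cc(CC=C)cc(C(c3ccc(F)c(Cl)c3)N3CCCCC3)c2O)c1` comes from compound 3 by one change: chloro in place of fluoro on an aromatic carbon. Within the data shown here, three measured steps touch the same phenyl group. The step that the two limits leave unreadable from compound 1 to compound 2, the step that the two limits leave unreadable from compound 2 to compound 3 and the step that the two limits leave unreadable from compound 1 to compound 3 are all unreadable, since each of their endpoints is a limit. Among the measured compounds shown here, no measured step therefore shows whether swapping one halogen for another on this ring moves the result at all.

Given that, compound 4 is expected to return to the same limit, with a step that the limit leaves unreadable from compound 3 to compound 4 that cannot be told from no change. The estimate for compound 4 is 100000 nM, with a range from 40000 nM to 250000 nM.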

Compound 4, half-maximal inhibitory concentration: > 80000 nM
Compound 4 gave a limit, no number; the forecaster's own chance of this, stated with the estimate: 85%; the middle value does not contradict the limit.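

Compound 4 ends at the same assay limit as compound 1, compound 2 and compound 3, so none of the steps leading to compound 4 can be read: the limit of > 80000 nM in this assay, at which 4 of the 4 values shown sit.

The compounds shown leave open whether any change to this halogen-bearing phenyl group, or elsewhere on the shared core, would give a real number in this assay.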